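The compounds below may be only part of what the source reports. "The series", "measured", "known", "first", "only" and "open" are said of these compounds alone.

Values in a physicochemical assay for lipophilicity, at pH 7.4; a higher number here means a more lipophilic compound, a lower number a more polar compound:

- Compound 1 `Cc1cc(C(=O)Nc2cccc(F)c2)nn1Cc1cc(Cl)ccc1OCc1ccccc1`: 2.8
- Compound 2 `CC(=O)Nc1cc(C)n(Cc2cc(Cl)ccc2OCc2ccccc2)n1`: > 3.7, a limit and not a number

Compound 2 therefore has no exact position on the scale, only a limit: the limit of > 3.7 in this assay, at which 1 of the 2 values shown sits.

The next compound is compound 3 `Cc1cc(NC(=O)C2CCCO2)nn1Cc1cc(Cl)ccc1OCc1ccccc1`, with the change oxolan-2-yl in place of methyl on a carbonyl carbon, turning acetamido into ((oxolan-2-yl)carbonyl)amino. Among the compounds with values here, the only measured step is a number at least 0.90 log units higher from compound 1 to compound 2 (beyond the scatter). It bears on this change only indirectly, since it is a different exchange, acetamido in place of (3-fluorophenyl)carbamoyl on an aromatic carbon, and its size is open-ended. No step beyond the scatter is therefore expected in this assay, and neither direction can be excluded. The expected change is a number at least 0.10 log units lower from compound 2 to compound 3 (that floor lies within the scatter), an estimate that rests on a limit. The estimate for compound 3 is 3.6, with an expected range of 3 to 4.1.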

Compound 3, distribution coefficient: > 3.7
Compound 3: a limit, no number; the forecaster's own chance of this, stated with the estimate: 40%; middle value at least 0.10 log units from the limit.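

In this assay compound 3 gives > 3.7, a limit and not a number. Exchanging (3-fluorophenyl)carbamoyl on the aromatic carbon for ((oxolan-2-yl)carbonyl)amino gives a number at least 0.90 log units higher from compound 1 to compound 3 (beyond the scatter), so the earlier rise seen with acetamido is not confined to that one amide. Placing oxolan-2-yl with its ring oxygen on the carbonyl carbon in place of methyl leaves the reading at the same limit, and the step from compound 2 to compound 3 cannot be read: the limit of > 3.7 in this assay, at which 2 of the 3 values shown sit.

As far as these compounds go, the size and direction of the difference between compound 2 and compound 3 remain open. Also open, from the compounds shown here alone, is whether a chain carrying an amine or a carboxylic acid on that carbonyl carbon would give an exact number in this assay.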